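The source may hold more compounds than are shown below. What is called first, only, known or untested is meant among the compounds shown, and "the series" means these compounds.

Measured so far:
Compound 1 `O=C(Nc1ccc(-c2ccccc2)cn1)Oc1ccccc1` gives 0% in an assay on isolated protein (Aquatica lateralis) for inhibition of Luciferin 4-monooxygenase (Luciola lateralis), read by a luciferase reporter, tested at 10 uM; on this read-out higher numbers stand for more inhibition at the one concentration tested (going by the name of the read-out) and lower numbers for less inhibition.
Compound 2 `O=C(Nc1ccc(-c2ccccc2)cn1)c1ccc(Cl)cc1` gives 0% in this assay.

Compound 2 stands level with compound 1 at the digits shown: the one step measured, no change at the digits printed from compound 1 to compound 2 (within the scatter), swapped a phenoxy for a 4-chlorophenyl on the carbonyl carbon and left the inhibition unchanged within the scatter. Neither compound inhibits the enzyme at the single concentration tested.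

Compound 3 `O=C(Nc1ccc(-c2ccccc2)cn1)c1ccc(Cl)c(Cl)c1` is the next compound to be measured. It differs from compound 2 in one place: chloro in place of hydrogen on an aromatic carbon. Among the compounds with values here, no measured step here touches a chloro group added to the ring on the carbonyl side, so the only guide is that compound 1 and compound 2 give inhibition in this assay that is level with each other, and a single added chlorine is a small change to a shared core whose numbers have so far not moved. A step of a number 5 percentage points higher from compound 2 to compound 3 (within the scatter) is expected, that is, no change beyond the scatter. Compound 3 is therefore estimated at 5%, within a range from 0% to 20%.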

Compound 3, a percentage reported as inhibition, at one concentration (the size of the read-out at that concentration, not a potency): 13%
Estimate against measurement, compound 3: 8 percentage points below; measured number inside the range.
By their numbers in this assay, from the lowest: compounds 1 and 2 (each within the scatter of the next); then compound 3.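

The chloro group in place of hydrogen on this aromatic carbon, ortho to a chloro group, gives a number 13 percentage points higher from compound 2 to compound 3 (beyond the scatter) in this assay. Within the data shown here, the earlier swap of phenoxy for 4-chlorophenyl on the carbonyl carbon gave no change at the digits printed from compound 1 to compound 2 (within the scatter), so this is the first single change here to move the read-out beyond the usual scatter, and it shows that this position can affect inhibition even though the step is modest. No available evidence bears on the reason for this rise.

On these data alone, it remains open whether the gain belongs to chloro itself or whether another group on the same carbon, such as methyl, methoxy or an amine, would give a similar or larger step. A reading at one concentration also leaves the potency of compound 3 unknown.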